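Swapping a Hydroxyphenyl for a Cyanopyridine in Dopamine Agonists

The source may hold more compounds than are shown below. What is called first, only, known or untested is meant among the compounds shown, and "the series" means these compounds.

Of the compounds shown here, three sharing one core have been tested in a functional assay on HEK293 cells for agonist activity at D(4) dopamine receptor (Homo sapiens), read by FLIPR; on this read-out lower numbers stand for an effect already at smaller amounts and higher numbers for an effect only at larger amounts of compound. Compound 1 `Cc1cccc(NC(=O)CN2CCC(c3cccc(O)c3)CC2)c1` gives 8 nM, the lowest of the three numbers. Compound 3 `COc1cccc(C)c1NC(=O)CN1CCC(c2ccccn2)CC1` gives 40 nM, a gap to compound 1 that lies beyond the usual scatter. Compound 2 `N#Cc1cccc(C(=O)NCN2CCC(c3cccc[n+]3[O-])CC2)c1` gives 840 nM, the number furthest from compound 1 and likewise beyond the scatter.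

Compound 4 `Cc1cccc(NC(=O)CN2CCC(c3cccc(C#N)n3)CC2)c1` has not yet been measured. It differs from compound 1 in a single place: 6-cyanopyridin-2-yl in place of 3-hydroxyphenyl on a saturated ring carbon. Within the data shown here, no pair of measured compounds differs in just one place, so the size of this step has no direct precedent. Some guidance comes because compound 3 gives 40 nM while carrying a pyridine ring on its saturated ring carbon. The step from compound 1 to compound 4 is therefore expected to be a 5.0-fold higher number from compound 1 to compound 4 (0.70 log units; beyond the scatter), toward a higher number and somewhat beyond the scatter. Compound 4 is estimated at 40 nM, with a range from 8 nM to 200 nM.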

Compound 4, half-maximal effective concentration: 36 nM
The estimate for compound 4 lay 1.1-fold (0.05 log units) above the measured number; measured number inside the range.
By their numbers in this assay, from the lowest: compound 1; then compounds 4 and 3 (each within the scatter of the next); then compound 2.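

In this assay, among these compounds, placing 6-cyanopyridin-2-yl instead of 3-hydroxyphenyl on the saturated ring carbon gives a 4.5-fold higher number from compound 1 to compound 4 (0.65 log units; beyond the scatter), a modest step and the first change in a single place in this set. Compound 4 still gives 36 nM although the entering group has 0 hydrogen-bond donors, so a hydroxyl group at this position is not required for an effect at double-digit nanomolar amounts. No measured property is available to explain the size of this step.

The change replaces the ring and its substituent at once, so the step cannot be divided between the ring nitrogen and the nitrile. On these data alone, it also remains open whether an amine or a carboxylic acid in place of the nitrile would bring the number closer to that of compound 1.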